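The source may hold more compounds than are shown below. What is called first, only, known or untested is meant among the compounds shown, and "the series" means these compounds.

Compound 3 `O=C(/C=C/c1ccc2c(c1)B(O)OC2)c1ccccc1F` carries a 2-fluorophenyl on the carbonyl carbon of the shared core. In a functional assay on MDA-MB-231 cells (Homo sapiens) for cytotoxicity, read by MTT assay, with a stated time of 48 h (on this read-out higher numbers stand for weaker inhibition and lower numbers for stronger inhibition), compound 3 gives 2200 nM. Going by the values given here, the only other number so far comes from compound 2 `O=C(/C=C/c1ccc2c(c1)B(O)OC2)c1ccc(F)cc1`, which in this assay gives 1600 nM, and the step of a 1.4-fold higher number from compound 2 to compound 3 (0.14 log units; within the scatter) stays within the scatter, so the two compounds stand together. Compound 1 `Cn1cccc1C(=O)/C=C/c1ccc2c(c1)B(O)OC2` reaches only a limit in this assay: > 100000 nM. The steps of an at least 62-fold lower number from compound 1 to compound 2 (1.79 log units; beyond the scatter) and an at least 45-fold lower number from compound 1 to compound 3 (1.65 log units; beyond the scatter) are large.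

Compound 4 `COc1ccccc1C(=O)/C=C/c1ccc2c(c1)B(O)OC2` differs from compound 3 by methoxy in place of fluoro on an aromatic carbon. Among the compounds with values here, no measured step swaps a fluoro for a methoxy. Within the data shown here, the only step between two aryl ketones, a 1.4-fold higher number from compound 2 to compound 3 (0.14 log units; within the scatter), was within the scatter, while the large steps from compound 1 replaced the whole group on the carbonyl carbon. The expectation in this assay is therefore a step of no change at the digits printed from compound 3 to compound 4 (within the scatter), no change beyond the scatter. Compound 4 is expected to give 2200 nM, between 800 nM and 6000 nM.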

Compound 4, half-maximal inhibitory concentration: 3100 nM
Compound 4: middle estimate off by 1.4-fold (0.15 log units), on the low side; measured number inside the range.
By their numbers in this assay, from the lowest: compounds 2, 3 and 4 (each within the scatter of the next). At a limit, above all of these: compound 1.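

In this assay, methoxy in place of fluoro on an aromatic carbon, ortho to a large group, gives a 1.4-fold higher number from compound 3 to compound 4 (0.15 log units; within the scatter). Going by these compounds alone, the earlier aryl ketones carried only fluoro, so this is the first sign that the group at this position can be exchanged for another without a step beyond the scatter. Nothing in the data shown accounts for this result.

As far as these compounds go, whether an amine, a carboxylic acid or a longer chain such as butoxy at this position would also stay within the scatter of compound 3 and compound 4 remains open.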